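Swapping the pyridine attachment point on the piperazine

The compounds below may be only part of what the source reports. "The series", "measured", "known", "first", "only" and "open" are said of these compounds alone.

Compound 1 `Nc1scc(CN2CCN(c3ccc(OC(F)(F)F)cc3)CC2)c1C(=O)c1ccc(Cl)cc1`: 0%
Compound 2 `Nc1scc(CN2CCN(c3cccnc3)CC2)c1C(=O)c1ccc(Cl)cc1`: 0%

In an assay on CHO cells for displacement of a labelled ligand from adenosine receptor A1 (Homo sapiens), read by scintillation counting, with a stated time of 120 min, tested at 10 uM (on this read-out lower numbers stand for less inhibition and higher numbers for more inhibition at the one concentration tested (going by the name of the read-out)), compound 1 gives 0%, and compound 2 gives 0%. Within the data shown here, the one measured step, no change at the digits printed from compound 1 to compound 2 (within the scatter), shows that replacing the larger aryl group on the ring amine nitrogen with the pyridine leaves the read-out where it was. Compound 2 therefore stands level with compound 1 within the scatter, with no inhibition recorded for either.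

Compound 3 `Nc1scc(CN2CCN(c3ccncc3)CC2)c1C(=O)c1ccc(Cl)cc1` differs from compound 2 only in the change (pyridin-4-yl in place of pyridin-3-yl on an amine nitrogen in a ring). Among the measured compounds shown here, no measured step bears on this exact change, so the only guide is the step from compound 1 to compound 2, which was flat even for a larger substitution at the same place. The expected step of no change at the digits printed from compound 2 to compound 3 (within the scatter) in this assay is accordingly none beyond the scatter. Compound 3 is estimated at 0%, within a range from -8% to 12%.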

Compound 3, a percentage reported as inhibition, at one concentration (the size of the read-out at that concentration, not a potency): 1%
Compound 3: middle estimate off by 1 percentage points, on the low side; the range from low to high includes it.
By their numbers in this assay, from the lowest: compounds 1, 2 and 3 (each within the scatter of the next).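

In this assay, moving the ring nitrogen of the pyridine gives a number 1 percentage points higher from compound 2 to compound 3 (within the scatter) and so adds something the earlier pair could not show: pyridin-4-yl and pyridin-3-yl, which have the same atoms joined differently, cannot be told apart at this place on the amine nitrogen in the ring. Set against the 4-(trifluoromethoxy)phenyl group, the pyridin-4-yl group gives a number 1 percentage points higher from compound 1 to compound 3 (within the scatter) and so all three groups stand level at the one concentration tested. Nothing at hand explains this flat read-out.

The compounds shown leave open whether any group at this place can raise the read-out beyond the scatter, such as a pyridin-2-yl ring, a carboxylic acid on the aryl ring or a longer chain on the amine nitrogen. They also leave open whether a change elsewhere on the shared core, such as an amide in place of the free amine, would do so.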